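The compounds below may be only part of what the source reports. "The series", "measured", "known", "first", "only" and "open" are said of these compounds alone.

Compound 2 `CC(C)(C)c1ccc(NC(=O)c2ccc(-c3ncccc3NC3CCCC3)cc2)cc1`: 44 nM
Compound 1 `N#Cc1ccc(NC(=O)c2ccc(-c3ncccc3C(F)(F)F)cc2)cc1`: 1300 nM

Of the compounds shown here, two have been measured in a functional assay for antagonist activity at transient receptor potential cation channel subfamily V member 1 (Rattus norvegicus); on this read-out higher numbers stand for weaker inhibition and lower numbers for stronger inhibition. Compound 2 gives 44 nM, the lower of the two numbers, so compound 2 stands as the stronger inhibitor here. Compound 1 gives 1300 nM, a gap far beyond the usual scatter. These two compounds differ in more than one place, so the gap between them cannot be tied to any single change.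

Compound 3 `Cc1nnc(-c2cccnc2-c2ccc(C(=O)Nc3ccc(C(C)(C)C)cc3)cc2)o1` has not yet been measured. It keeps the shared core of compound 2 and differs in one place: 5-methyl-1,3,4-oxadiazol-2-yl in place of cyclopentylamino on an aromatic carbon. Within the data shown here, no measured pair shows the effect of this exchange on its own, so the expectation rests on compound 2 alone and on the observation that compound 1, the only other reference, lies well above it. A step in this assay toward a higher number, of moderate size and beyond the scatter, is expected, though with real uncertainty. Compound 3 is expected to give 300 nM in this assay, with a likely range from 60 nM to 1500 nM. This estimate corresponds to an expected step of a 6.8-fold higher number from compound 2 to compound 3 (0.83 log units; beyond the scatter).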

Compound 3, half-maximal inhibitory concentration: 34 nM
Compound 3: the middle estimate sits 8.8-fold (0.95 log units) above what was measured, outside the stated range (below it).
By their numbers in this assay, from the lowest: compounds 3 and 2 (each within the scatter of the next); then compound 1.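

In this assay, placing 5-methyl-1,3,4-oxadiazol-2-yl in place of cyclopentylamino gives a 1.3-fold lower number from compound 2 to compound 3 (0.11 log units; within the scatter), so this read-out does not separate the two groups. The exchange is far from a small one: on this aromatic carbon, ortho to a large group, a five-membered non-aromatic ring of carbon only, carrying a hydrogen-bond donor, gives way to a five-membered aromatic ring with 3 hetero atoms and no hydrogen-bond donor, so at this position in this pair, neither that donor nor a non-aromatic ring is required for a number at this level. No independent measurement is available to explain why these two different groups give matching results.

Compound 1 differs from compound 2 in more than one place, so what its trifluoromethyl group does at this position cannot be separated from its other change. Going by these compounds, it remains open whether a smaller group such as methyl, a primary amine or a carboxylic acid on this same carbon would also give a number in the range of compound 2 and compound 3.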